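Configuration change at a saturated chain carbon

The source may report more compounds than this note shows. Statements on the series, on what has been measured and on what is new or still open speak of the compounds shown alone.

Values in an ADME assay on MRC5 cells (Homo sapiens) for inhibition, read by MTT assay, with a stated time of 72 h; on this read-out higher numbers stand for weaker inhibition and lower numbers for stronger inhibition:
compound 1 `CO[C@@H]1[C@H]2OC(=O)C[C@H]2O[C@@H]1[C@@H](OC)c1ccccc1`: 87600 nM
compound 2 `CO[C@@H]1[C@H]2OC(=O)C[C@H]2O[C@@H]1[C@@H](O)c1ccccc1`: > 100000 nM, a limit of the assay
compound 3 `CO[C@@H]1[C@H]2OC(=O)C[C@H]2O[C@@H]1C(O)(c1ccccc1)c1ccccc1`: > 100000 nM, a limit of the assay

Going by the values given here, compound 1 carries the only number in this set; compounds 2 and 3 report a limit, (the limit of > 100000 nM in this assay, at which 2 of the 3 values shown sit). Among the compounds with values here, the one measured step, an at least 1.1-fold higher number from compound 1 to compound 2 (0.05 log units; that floor lies within the scatter), is within the scatter. Compound 4 `CO[C@@H]1[C@H]2OC(=O)C[C@H]2O[C@@H]1[C@H](OC)c1ccccc1` differs from compound 1 by the two compounds have the same atoms and bonds and differ only in configuration as drawn: 1 of 5 stereo elements differ; a stereocentre at a saturated chain carbon is drawn S in compound 1 and R in compound 4. Within the data shown here, no measured step changes a configuration, so none bears on this change directly, and the only step recorded is small. Compound 4 is therefore expected to stay near compound 1, with a 1.1-fold higher number from compound 1 to compound 4 (0.04 log units; within the scatter) as the expected step, not beyond the scatter. The estimate for compound 4 is 95000 nM, expected between 45000 nM and 200000 nM, with a fair chance that only a limit is reported.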

Compound 4, half-maximal inhibitory concentration: > 100000 nM
Compound 4: a limit, no number; the forecaster's own chance of this, stated with the estimate: 50%; at least 1.0-fold (0.02 log units) between middle value and limit.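

In this assay, going by these compounds alone, the change of configuration at the saturated chain carbon gives an at least 1.1-fold higher number from compound 1 to compound 4 (0.05 log units; that floor lies within the scatter), the first direct reading on this stereocentre; the size of the step beyond that floor cannot be read. The value of compound 4 is a limit, not a number. Compound 1 remains the only compound with a number, and the S and R forms cannot be ranked: the limit of > 100000 nM in this assay, at which 3 of the 4 values shown sit.

As far as these compounds go, whether an amine or a longer chain on this carbon would give a number clearly lower than that of compound 1 stays open. From the compounds shown here alone, how far compound 4 lies past its limit also stays open.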